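Tertiary amide variants of the stilbene cinnamamide series

The compounds below may be only part of what the source reports. "The series", "measured", "known", "first", "only" and "open" are said of these compounds alone.

Measured compounds in a functional assay on MCF7 cells (Homo sapiens) for inhibition, read by MTT assay, with a stated time of 48 h; a lower number here means a stronger inhibitor, a higher number a weaker inhibitor:
compound 1 `CCCCNC(=O)/C=C/c1c(/C=C/c2ccc(OC)cc2)cc(OC)cc1OC`, 1330 nM
compound 2 `CCC(C)NC(=O)/C=C/c1c(/C=C/c2ccc(OC)cc2)cc(OC)cc1OC`, 3430 nM
compound 3 `CCCCN(CCCC)C(=O)/C=C/c1c(/C=C/c2ccc(OC)cc2)cc(OC)cc1OC`, 3990 nM

Compound 3 holds the highest number of the three in this assay; compound 2 sits within the scatter of it, compound 1 lies beyond the scatter below.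

Compound 4 `COc1ccc(/C=C/c2cc(OC)cc(OC)c2/C=C/C(=O)N2CCC(c3ccccc3)CC2)cc1` differs from compound 3 in one place: 4-phenylpiperidin-1-yl in place of dibutylamino on a carbonyl carbon. The bearing steps are a 3.0-fold higher number from compound 1 to compound 3 (0.48 log units; beyond the scatter) and a 1.2-fold higher number from compound 2 to compound 3 (0.07 log units; within the scatter); both compare amide nitrogen substituents, and only the change from a free to a fully substituted nitrogen moved the number beyond the scatter. Compound 4 keeps a fully substituted nitrogen, so in this assay no step beyond the scatter is expected from compound 3, a 1.0-fold higher number from compound 3 to compound 4 (0.00 log units; within the scatter).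

Compound 4 is therefore estimated at 4000 nM, within 1500 nM to 12000 nM.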

Compound 4, half-maximal inhibitory concentration: 4230 nM
Estimate against measurement, compound 4: 1.1-fold (0.02 log units) below; low and high end bracket the measured number.
By their numbers in this assay, from the lowest: compound 1; then compounds 2, 3 and 4 (each within the scatter of the next).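

In this assay, 4-phenylpiperidin-1-yl on the carbonyl carbon, with its two rings, reads the same as open-chain dibutylamino, with a 1.1-fold higher number from compound 3 to compound 4 (0.03 log units; within the scatter), and as (sec-butyl)amino, with a 1.2-fold higher number from compound 2 to compound 4 (0.09 log units; within the scatter). Only the butylamino amide stands apart, with a 3.2-fold higher number from compound 1 to compound 4 (0.50 log units; beyond the scatter). No evidence accompanies these numbers to account for them.

Still open, from the compounds shown here alone, is whether plain piperidin-1-yl or morpholin-4-yl on the carbonyl carbon would read the same as compound 4. Also open, going by these compounds, is whether a secondary amide carrying a longer chain, such as hexylamino, would stay near compound 1.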